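The source may hold more compounds than are shown below. What is called first, only, known or untested is meant among the compounds shown, and "the series" means these compounds.

Measured so far:
- compound 1, `Nc1ncnc2c1c(-c1ccc3cc[nH]c3c1)cn2-c1ccc(OCCNCCO)cc1`: 220 nM
- compound 2, `CN(C)Cc1ccc(-n2cc(-c3ccc4cc[nH]c4c3)c3c(Cl)ccnc32)cc1`: 120 nM
- compound 3, `NC(=O)CCn1cc(-c2ccc3cc[nH]c3c2)c(C(F)(F)F)n1`: 4200 nM

In an assay on isolated protein for inhibition of Myeloperoxidase (Homo sapiens) (on this read-out lower numbers stand for stronger inhibition and higher numbers for weaker inhibition), compound 3 gives the highest number of the three; compound 1 sits a long way lower, and compound 2 lower still, both gaps beyond the scatter. Among the compounds with values here, compounds 1 and 2 share a core that compound 3 does not, so no single structural step connects them to compound 3, and their values are only a backdrop.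

Compound 4, `NC[C@H]1C[C@H](n2cc(-c3ccc4cc[nH]c4c3)c(C(F)(F)F)n2)C1`, differs from compound 3 by a group of 6 heavy atoms (5 carbon, 1 nitrogen; one four-membered non-aromatic ring of carbon only) in place of a group of 5 heavy atoms (3 carbon, 1 nitrogen, 1 oxygen; no ring), on an aromatic nitrogen, on an aromatic nitrogen of a five-membered aromatic ring with two nitrogens, next to the ring nitrogen, two ring bonds from the ring atom bearing the trifluoromethyl group. Within the data shown here, no measured pair shows this change, so the size of the step is uncertain. Given that compound 3 gives 4200 nM, the expected step is a 3.5-fold lower number from compound 3 to compound 4 (0.54 log units; beyond the scatter), a modest move toward a lower number, with wide uncertainty. Compound 4 is therefore estimated at 1200 nM, within 300 nM to 5000 nM.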

Compound 4, half-maximal inhibitory concentration: 170 nM
Estimate against measurement, compound 4: 7.1-fold (0.85 log units) above, and the stated range ends above it.
By their numbers in this assay, from the lowest: compounds 2, 4 and 1 (each within the scatter of the next); then compound 3.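

In this assay, the group on the aromatic nitrogen of the five-membered aromatic ring is the one place where a single change can be read, and replacing 2-carbamoylethyl with the group holding a four-membered carbon ring gives a 25-fold lower number from compound 3 to compound 4 (1.39 log units; beyond the scatter). Both groups have the same hydrogen-bond donor and acceptor counts and no net charge, so those counts do not separate them, while the ring, the loss of the double bond and the two defined stereocentres all enter in the same step. Nothing available bears on the reason for the size of this step.

This one pair cannot show which of those differences carries the step. On these data alone, how an open-chain amine or a carboxylic acid would read on this nitrogen remains open, as does the opposite arrangement at the two stereocentres.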